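The source may hold more compounds than are shown below. What is called first, only, known or untested is meant among the compounds shown, and "the series" means these compounds.

Measured so far: compound 1 `Fc1cccc(-c2cn(C3CN4CCC3CC4)nn2)c1` gives 5.24 nM; compound 2 `Fc1ccc(COc2cccc(-c3cn(C4CN5CCC4CC5)nn3)c2)cc1` gives 13.9 nM; compound 3 `Fc1cccc(-c2cn([C@H]3CN4CCC3CC4)nn2)c1` gives 362 nM. All three numbers come from an assay on HEK293 cells for displacement of a labelled ligand from Neuronal acetylcholine receptor; alpha3/beta4 (Homo sapiens), read by scintillation counting, with a stated time of 120 min; a higher number here means a weaker inhibitor, a lower number a stronger inhibitor.

The two measured steps start from compound 1. Moving to compound 2 changes the structure in one place, ((4-fluorobenzyl)oxy in place of fluoro on an aromatic carbon), and the result is a 2.7-fold higher number from compound 1 to compound 2 (0.42 log units; beyond the scatter). Moving to compound 3 changes nothing in the atoms and bonds; the difference is the two compounds have the same atoms and bonds; at least one stereo element is drawn with a configuration in one of them and without one in the other: 1 of 3 stereo elements differ; a stereocentre at a saturated ring carbon is drawn without a configuration in compound 1 and R in compound 3, and the result is a 69-fold higher number from compound 1 to compound 3 (1.84 log units; beyond the scatter). That large step is tied to the fact that (the fact that one of compounds 1 and 3 is drawn with a defined configuration and the other without, at the place where they differ), so compound 3 stands as the weakest of the three measured compounds in this assay.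

Compound 4 `Fc1ccc(COc2cccc(-c3cn([C@H]4CN5CCC4CC5)nn3)c2)cc1` is not yet measured. Among the measured compounds shown here, its relation to compound 3 is (4-fluorobenzyl)oxy in place of fluoro on an aromatic carbon, which is the same change as the one that turned compound 1 into compound 2, made on the same place. Resting on the step seen from compound 1 to compound 2, a 2.7-fold higher number from compound 1 to compound 2 (0.42 log units; beyond the scatter), compound 4 is expected to give a number modestly higher than compound 3, a step of about a 2.6-fold higher number from compound 3 to compound 4 (0.42 log units; beyond the scatter). The expected value for compound 4 in this assay is therefore 950 nM.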

Compound 4, inhibition constant: 1090 nM
For compound 4 the middle estimate is 1.1-fold (0.06 log units) below the measured one, within the range that was stated.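

In this assay, putting (4-fluorobenzyl)oxy in place of fluoro on the core of compound 3 gives a 3.0-fold higher number from compound 3 to compound 4 (0.48 log units; beyond the scatter), and this matches the earlier step on the core of compound 1: the same change on two cores in this assay, a 2.7-fold higher number (0.42 log units; beyond the scatter) from compound 1 to compound 2 and a 3.0-fold higher number (0.48 log units; beyond the scatter) from compound 3 to compound 4, 1.1-fold (0.06 log units) apart, within the scatter of two such steps. The change therefore carries over between these two cores at about the same size, and the large stereo gap also appears again with the larger group in place, as a 78-fold higher number from compound 2 to compound 4 (1.89 log units; beyond the scatter), which goes with this difference in the drawings: the fact that one of compounds 2 and 4 is drawn with a defined configuration and the other without, at the place where they differ. These two cores have the same atoms and bonds, however, so the two pairs show nothing about a core built differently, and they do not explain the size of either step.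

From the compounds shown here alone, it remains open whether another group on that aromatic carbon, such as an amine, a carboxylic acid or a longer chain, would shift the number by a similar amount on both cores. Also open, going by these compounds, is how a compound drawn with the S configuration at that saturated ring carbon would read in this assay.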